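The compounds below may be only part of what the source reports. "The series", "measured", "known", "first", "only" and "open" are said of these compounds alone.

Compound 1 `CC1=CC[C@H](C(C)(C)NC(=S)NN)CC1` is the smaller of the two measured compounds; in a functional assay on OVCAR-3 cells (Homo sapiens) for inhibition, read by sulforhodamine B assay, with a stated time of 48 h (a higher number here means a weaker inhibitor of growth, a lower number a stronger inhibitor of growth), compound 1 gives 41900 nM. Compound 2 `CC1=CC[C@H](C(C)(C)NC(=S)N/N=C(\C)c2ccccc2)CC1` adds a larger group to the same core. In this assay compound 2 gives only a limit, > 100000 nM, so it sits at the limit of > 100000 nM in this assay, at which 1 of the 2 values shown sits, rather than at a number. Compound 3 `COc1ccc(/C(C)=N/NC(=S)NC(C)(C)[C@H]2CC=C(C)CC2)cc1` differs from compound 2 by methoxy in place of hydrogen on an aromatic carbon, which is a methoxy in place of hydrogen on an aromatic carbon. For the measured compounds named here, no measured pair shows what such a change does here, so the expected shift is a number no higher from compound 2 to compound 3 (the limit leaves the size open), within the scatter. Compound 3 is therefore estimated at 100000 nM, within 40000 nM to 300000 nM.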

Compound 3, concentration for 50% growth inhibition: 74900 nM
For compound 3 the middle estimate is 1.3-fold (0.13 log units) above the measured one; low and high end bracket the measured number.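

The change from phenyl to 4-methoxyphenyl gives an at least 1.3-fold lower number from compound 2 to compound 3 (0.12 log units; that floor lies within the scatter). With the methoxy on this aromatic carbon, compound 3 reads as a number, 74900 nM, whereas the earlier phenyl compound did not. The true size of the step stays unknown, since compound 2 stands at a limit and only a floor can be read: the limit of > 100000 nM in this assay, at which 1 of the 3 values shown sits.

Going by these compounds, whether an amine, a carboxylic acid or a longer chain at this same place would move the number further remains open. So does the effect of a methoxy elsewhere on this aromatic ring.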